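The source may hold more compounds than are shown below. What is called first, only, known or untested is meant among the compounds shown, and "the series" means these compounds.

Measured so far in an ADME assay on MCF-10A cells (Homo sapiens) for inhibition, read by MTT assay, with a stated time of 48 h, tested at 2 uM; on this read-out higher numbers stand for more inhibition at the one concentration tested (going by the name of the read-out) and lower numbers for less inhibition:
Compound 1, `Cc1noc(C)c1-c1ccc2c(c1)C(c1ccccc1)NC(=O)N2C`, gives 6.8%.
Compound 2, `Cc1noc(C)c1-c1ccc2c(c1)C(c1ccccc1)N(Cc1nnc(-c3ccccc3)o1)C(=O)N2C`, gives 12.4%.

Both numbers are small, so neither compound does much at the single concentration tested. For the measured compounds named here, compound 2 stands alongside compound 1 rather than apart from it: the only measured step, a number 5.6 percentage points higher from compound 1 to compound 2 (within the scatter), lies within the scatter, so the two compounds cannot be told apart on these numbers.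

Compound 3, `Cc1noc(C)c1-c1ccc2c(c1)C(c1ccccc1)N(Cc1ncc(-c3ccccc3)o1)C(=O)N2C`, has not yet been measured in this assay. It differs from compound 2 in one place: 5-phenyl-1,3-oxazol-2-yl in place of 5-phenyl-1,3,4-oxadiazol-2-yl on a saturated chain carbon bound to an amide-type nitrogen in a ring. The group that leaves and the group that enters are each a phenyl-bearing five-membered aromatic ring sitting on the same saturated chain carbon bound to an amide-type nitrogen in a ring.

Going by the values given here, no measured step bears directly on this exchange. Among the compounds with values here, the one step that exists adds the whole side chain to the shared core and still stays within the scatter; swapping one heteroatom ring for another inside that chain gives no ground to expect anything larger. Compound 3 is therefore expected to give 12%, with a range from 2% to 24%. The expected step is a number 0.4 percentage points lower from compound 2 to compound 3 (within the scatter), that is, none beyond the scatter.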

Compound 3, a percentage reported as inhibition, at one concentration (the size of the read-out at that concentration, not a potency): 3.7%
Compound 3: middle estimate off by 8.3 percentage points, on the high side, and the stated range covers the measured number.
By their numbers in this assay, from the lowest: compounds 3, 1 and 2 (each within the scatter of the next).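

In this assay, putting 5-phenyl-1,3-oxazol-2-yl in place of 5-phenyl-1,3,4-oxadiazol-2-yl on the saturated chain carbon bound to an amide-type nitrogen in a ring gives a number 8.7 percentage points lower from compound 2 to compound 3 (within the scatter) and so does not separate the two compounds. This exchange of a ring nitrogen for a ring carbon therefore has no effect that can be read on these numbers. Compared with the amide hydrogen of compound 1, the (5-phenyl-1,3-oxazol-2-yl)methyl group gives a number 3.1 percentage points lower from compound 1 to compound 3 (within the scatter) and so also cannot be told apart from having no side chain at this position, while no supporting measurement is available to explain any of these small differences.

So far, no group at this position moves the number beyond the scatter, at the one concentration tested. From the compounds shown here alone, it remains open whether an amine or a carboxylic acid in place of the phenyl group, or a longer chain joining the five-membered ring to the amide-type nitrogen, would give a clearly different number in this assay and show that this position matters at all.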